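From methyl to benzyl on the methoxy compound

The source may hold more compounds than are shown below. What is called first, only, known or untested is meant among the compounds shown, and "the series" means these compounds.

Numbers so far exist for three compounds sharing one core. In a functional assay on MCF7 cells (Homo sapiens) for antiproliferative activity, read by MTT assay, with a stated time of 72 h (on this read-out lower numbers stand for stronger inhibition and higher numbers for weaker inhibition), compound 1 (`CCOC(=O)c1csc2nc(CN3CCN(C)CC3)c(-c3ccc(C)cc3)n12`) gives 58300 nM as its result, and compound 2 (`CCOC(=O)c1csc2nc(CN3CCN(Cc4ccccc4)CC3)c(-c3ccc(C)cc3)n12`) gives 29100 nM as its result. Compound 3 (`CCOC(=O)c1csc2nc(CN3CCN(C)CC3)c(-c3ccc(OC)cc3)n12`) gives 32800 nM and sits with the other two, as no gap among the three goes beyond the scatter.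

Compound 4 (`CCOC(=O)c1csc2nc(CN3CCN(Cc4ccccc4)CC3)c(-c3ccc(OC)cc3)n12`) keeps the methoxy of compound 3 and swaps methyl for benzyl, which is phenyl in place of hydrogen on a saturated chain carbon bound to an amine nitrogen in a ring. The same swap has been seen once, as a 2.0-fold lower number from compound 1 to compound 2 (0.30 log units; within the scatter) and this is the closest guide. The methoxy in place of methyl step, a 1.8-fold lower number from compound 1 to compound 3 (0.25 log units; within the scatter) and already built into the starting point, is the other relevant measurement. Nothing yet shows whether the two changes add up.

The expected step in this assay is therefore a 1.7-fold lower number from compound 3 to compound 4 (0.24 log units; within the scatter) toward a lower number, with nothing beyond the scatter foreseen. Compound 4 is expected near 19000 nM with an estimated range of 8500 nM to 42000 nM around that middle.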

Compound 4, half-maximal inhibitory concentration: 17100 nM
Compound 4: middle estimate off by 1.1-fold (0.05 log units), on the high side; measured number inside the range.
By their numbers in this assay, from the lowest: compounds 4, 2, 3 and 1 (each within the scatter of the next, the first and the last beyond it).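

Compound 4 carries both changes, so each now has a second reading in this assay: a 1.9-fold lower number from compound 3 to compound 4 (0.28 log units; within the scatter) for phenyl in place of hydrogen on a saturated chain carbon bound to an amine nitrogen in a ring, and a 1.7-fold lower number from compound 2 to compound 4 (0.23 log units; within the scatter) for methoxy in place of methyl on an aromatic carbon. The methyl to benzyl swap gives much the same step with methoxy present as with methyl: the same change on two cores in this assay, a 2.0-fold lower number (0.30 log units; within the scatter) from compound 1 to compound 2 and a 1.9-fold lower number (0.28 log units; within the scatter) from compound 3 to compound 4, 1.0-fold (0.02 log units) apart, within the scatter of two such steps The methoxy swap likewise gives much the same step with benzyl present as without it, so in these four compounds the two changes simply add up: the same change on two cores in this assay, a 1.8-fold lower number (0.25 log units; within the scatter) from compound 1 to compound 3 and a 1.7-fold lower number (0.23 log units; within the scatter) from compound 2 to compound 4, 1.0-fold (0.02 log units) apart, within the scatter of two such steps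

Each single step still lies within the scatter, so neither change is established on its own. Open, from the compounds shown here alone, is whether a longer chain ending in phenyl, or a phenyl carrying a carboxylic acid, would give a step beyond the scatter at this place.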